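From butyl to propyl on a shared core

The compounds below may be only part of what the source reports. "The series", "measured", "known", "first", "only" and "open" are said of these compounds alone.

Of the compounds shown here, three with a shared core have been measured so far. In a functional assay on HCT-8 cells (Homo sapiens) for antiproliferative activity, read by sulforhodamine B assay, with a stated time of 3 days (a lower number here means that less compound is needed, a higher number that more compound is needed for the effect), compound 1 (`CCCC1=C(OCCC(C)C)C(CCC)(CCC)C(=O)/C(=C(O)\C=C\c2ccccc2)C1=O`) gives 15.3 uM while compound 2 (`CCCCOC1=C(CCC)C(=O)/C(=C(O)/C=C/c2ccccc2)C(=O)C1(CCC)CCC`) gives 8.7 uM and compound 3 (`COC1=C(CC=C(C)C)C(=O)/C(=C(O)/C=C/c2ccccc2)C(=O)C1(CC=C(C)C)CC=C(C)C`) gives 13.7 uM in the same test. Compound 2 therefore stands within the scatter of both other compounds, and these numbers do not separate it from either one.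

The next compound to be tested is compound 4 (`CCCOC1=C(CCC)C(=O)/C(=C(O)/C=C/c2ccccc2)C(=O)C1(CCC)CCC`). Going from compound 2 to compound 4, the difference is hydrogen in place of methyl on a saturated chain carbon, three bonds along the chain from an oxygen on an unsaturated carbon and it reads as butyl to propyl. Among the compounds with values here, only one measured step bears on this change. That step is a 1.8-fold lower number from compound 1 to compound 2 (0.25 log units; within the scatter) and it also puts hydrogen in place of methyl, though on a saturated chain carbon bound to two saturated chain carbons. It is a single step at a different place on the chain, and it stays within the scatter. No step beyond the scatter is therefore expected in this assay and no direction can be claimed. The estimated change is a 1.1-fold higher number from compound 2 to compound 4 (0.04 log units; within the scatter) and it would be too small to read. Compound 4 is estimated at 9.5 uM with an expected range from 5 uM to 18 uM for its measured value.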

Compound 4, concentration for half-maximal effect: 2.6 uM
Compound 4: the middle estimate sits 3.7-fold (0.56 log units) above what was measured; measured number below the stated range.
By their numbers in this assay, from the lowest: compound 4; then compounds 2, 3 and 1 (each within the scatter of the next).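

In this assay the change from butyl to propyl gives a 3.3-fold lower number from compound 2 to compound 4 (0.52 log units; beyond the scatter) and so shows that this place on the chain, three bonds along from an oxygen on an unsaturated carbon, can respond to the loss of a single methyl, whereas the earlier 1.8-fold lower number from compound 1 to compound 2 (0.25 log units; within the scatter) did not separate its two compounds. The further a 5.9-fold lower number from compound 1 to compound 4 (0.77 log units; beyond the scatter) comes with methyl in place of isopropyl on a saturated chain carbon, two bonds along the chain from that oxygen, and it also lies beyond the scatter, so the propyl chain of compound 4 stands clear of both the butyl chain of compound 2 and the chain of compound 1. No measurement at hand accounts for the size of these steps.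

The compounds shown leave open whether the gain continues, stops or reverses with an ethyl chain in this place, and whether a pentyl or hexyl chain would behave as the butyl chain does. They also leave open whether an amine or a carboxylic acid at the end of the propyl chain would keep the number of compound 4.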